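Ethylamino in Place of Methoxy on the Shared Core

This account rests on a few compounds, and the source may have more. Where it says the series, first, only, none or still open, it means among the compounds named here.

Measured compounds:
- compound 1, `CNc1cc(Oc2ccc(NC(=O)Nc3cccc(C(F)(F)F)c3)c(F)c2)ncn1`: 63 nM
- compound 2, `COc1cc(Oc2ccc(NC(=O)Nc3cccc(C(F)(F)F)c3)cc2)ncn1`: 4000 nM
- compound 3, `CNc1cc(Oc2ccc(NC(=O)Nc3cccc(C)c3)cc2)ncn1`: 1260 nM

In an assay on isolated protein for inhibition of serine/threonine-protein kinase TNNI3K (Homo sapiens) (on this read-out lower numbers stand for stronger inhibition and higher numbers for weaker inhibition), compound 2 gives 4000 nM, the highest of the three numbers; compound 3 comes nearest with 1260 nM, and compound 1 is furthest with 63 nM. Compound 4, `CCNc1cc(Oc2ccc(NC(=O)Nc3cccc(C(F)(F)F)c3)cc2)ncn1`, has not yet been measured. It differs from compound 2 by ethylamino in place of methoxy on an aromatic carbon. Both compounds that carry an amino group on the core, compound 1 and compound 3, give lower numbers than compound 2, so a lower number is expected for compound 4 as well, though compound 1 also differs from compound 2 elsewhere. The step of a 10-fold lower number from compound 2 to compound 4 (1.00 log units; beyond the scatter) is expected to lie beyond the scatter. Compound 4 is estimated at 400 nM, with a range from 100 nM to 1600 nM.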

Compound 4, half-maximal inhibitory concentration: 25 nM
The estimate for compound 4 lay 16-fold (1.20 log units) above the measured number; measured number outside the range, below it.
By their numbers in this assay, from the lowest: compound 4; then compound 1; then compound 3; then compound 2.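

In this assay, ethylamino in place of methoxy on this aromatic carbon of the shared core gives a 160-fold lower number from compound 2 to compound 4 (2.20 log units; beyond the scatter) with nothing else on the molecule changed. This is the first comparison among these compounds that differs in one place only, so it ties a large change in the read-out to this position alone, which the earlier compounds, differing in more than one place, could not do.

The compounds shown leave open whether a plain amine, propylamino or a ring amine such as morpholine at this position would give a similar number. No measurement shown bears on why the step is this large.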